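Cyclobutyl becomes cyclopentyl on compound 3

The source may hold more compounds than are shown below. What is called first, only, known or untested is meant among the compounds shown, and "the series" means these compounds.

A compound is partly held by proteins and partly free, and the free share can be measured directly. In an ADME assay on the whole organism (plasma, Rattus norvegicus, strain Sprague-Dawley) for protein binding, read by LC-MS, with a stated time of 24 h (on this read-out lower numbers stand for a smaller free fraction and higher numbers for a larger free fraction), compound 1 `CN(C(=O)OCc1c(-c2ccc(O[C@H]3CCC[C@H](C(=O)O)C3)cc2)cnn1C)C1CCCC1` gives 0.009 and compound 2 `Cc1noc(-c2ccc(Oc3ccc(C(=O)O)cc3)cc2)c1NC(=O)O[C@H](C)c1ccccc1` gives 0.001. Compound 3 `Cc1nc(-c2nnn(C)c2COC(=O)N(C)CC2CCC2)ccc1O[C@H]1CCC[C@H](C(=O)O)C1` gives 0.053, the highest of the three numbers, and its gaps to both others lie beyond the usual scatter.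

Compound 4 `Cc1nc(-c2nnn(C)c2COC(=O)N(C)CC2CCCC2)ccc1O[C@H]1CCC[C@H](C(=O)O)C1` differs from compound 3 in one place: cyclopentyl in place of cyclobutyl on a saturated chain carbon bound to an amide-type nitrogen. Going by the values given here, no two measured compounds differ in only one place, so the data offer no direct guide to this swap. Starting from compound 3 at 0.053, a slight fall in this assay is expected, most likely within the scatter. The expected step is a 1.5-fold lower number from compound 3 to compound 4 (0.17 log units; within the scatter). The estimate for compound 4 is 0.036, with a range from 0.018 to 0.07.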

Compound 4, unbound fraction: 0.047
Beside the measured number, compound 4's estimate is 1.3-fold (0.12 log units) below it, within the range that was stated.
By their numbers in this assay, from the lowest: compound 2; then compound 1; then compounds 4 and 3 (each within the scatter of the next).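

In this assay, replacing cyclobutyl with cyclopentyl on a saturated chain carbon bound to an amide-type nitrogen gives a 1.1-fold lower number from compound 3 to compound 4 (0.05 log units; within the scatter) and so the two compounds cannot be told apart. Going by these compounds alone, this is the first pair here that differs in only one place, and it shows that, on this core, the four-membered and five-membered carbon rings give the same free fraction within the scatter. Nothing available gives a cause for this result.

Both rings contain only carbon, so this single pair cannot show how much change this position accepts. From the compounds shown here alone, whether a cyclohexyl ring, a longer chain such as hexyl, or a ring carrying an amine would shift the free fraction beyond the scatter remains open.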